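From 4-methoxyphenyl to 3,4,5-trihydroxyphenyl: notes on compound 3

The source may hold more compounds than are shown below. What is called first, only, known or untested is meant among the compounds shown, and "the series" means these compounds.

In a physicochemical assay, read by spectrophotometry, with a stated time of 6 min (on this read-out higher numbers stand for weaker inhibition and lower numbers for stronger inhibition), compound 1 (`O=C(CCc1nc2ccccc2c(=O)[nH]1)N/N=C/c1ccccc1`) gives 265000000 nM and compound 2 (`COc1ccc(/C=N/NC(=O)CCc2nc3ccccc3c(=O)[nH]2)cc1`) gives 75000000 nM. Compound 2 therefore holds the lower of the two numbers, which means the stronger inhibition of the pair.

Compound 3 (`O=C(CCc1nc2ccccc2c(=O)[nH]1)N/N=C/c1cc(O)c(O)c(O)c1`) carries 3,4,5-trihydroxyphenyl in place of 4-methoxyphenyl on a carbon with a double bond to nitrogen.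

For the measured compounds named here, only one measured step bears on this change: a 3.5-fold lower number from compound 1 to compound 2 (0.55 log units; beyond the scatter). That step is modest but beyond the scatter, and it accompanies methoxy in place of hydrogen on an aromatic carbon. Going by the values given here, it offers a loose guide only, since no compound with a hydroxy-bearing ring has been measured. The direction is carried over from it, and a larger size is assumed given the greater oxygen count of the entering group.

The expected change is a 9.4-fold lower number from compound 2 to compound 3 (0.97 log units; beyond the scatter), towards stronger inhibition. In this assay the estimated value for compound 3 is 8000000 nM, expected to fall within 300000 nM to 60000000 nM.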

Compound 3, half-maximal inhibitory concentration: 35000000 nM
Beside the measured number, compound 3's estimate is 4.4-fold (0.64 log units) below it; the range from low to high includes it.
By their numbers in this assay, from the lowest: compound 3; then compound 2; then compound 1.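

The carbon with a double bond to nitrogen now carries a third ring, and the number falls again in this assay: 3,4,5-trihydroxyphenyl in place of 4-methoxyphenyl gives a 2.1-fold lower number from compound 2 to compound 3 (0.33 log units; beyond the scatter), and 3,4,5-trihydroxyphenyl in place of phenyl gives a 7.6-fold lower number from compound 1 to compound 3 (0.88 log units; beyond the scatter). A lower number at this position is therefore not tied to methoxy, since a ring bearing only hydroxy groups also lowers it, and neither of the substituted rings goes against the order set by unsubstituted phenyl. With both steps beyond the scatter, compound 3 shows the strongest inhibition of the three, although each step is rated modest and the numbers remain large.

The three compounds do not separate the effect of hydroxy groups from the effect of having several oxygen-bearing groups on the ring, a question that 4-hydroxyphenyl and 3,4,5-trimethoxyphenyl at the same place would address. On these data alone, a carboxylic acid or an amine on the ring, and a longer chain between the shared core and the carbon with a double bond to nitrogen, also remain open. No available evidence accounts for the size or direction of these steps.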